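Moving from a urea back to an amide with an added chlorine

The source may report more compounds than this note shows. Statements on the series, on what has been measured and on what is new or still open speak of the compounds shown alone.

Going by the values given here, the two compounds measured so far share one core and differ only in the group on the carbonyl carbon. Compound 1 `COc1cc(-c2nn(-c3cccc(NC(=O)c4cccc(C(F)(F)F)c4)c3)cc2-c2ccncc2)ccc1Cl` gives 1240 nM in a functional assay on MDA-MB-231 cells (Homo sapiens) for inhibition, read by sulforhodamine B assay, with a stated time of 48 h; a higher number here means a weaker inhibitor of growth, a lower number a stronger inhibitor of growth. Compound 2 `COc1cc(-c2nn(-c3cccc(NC(=O)Nc4cccc(C(F)(F)F)c4)c3)cc2-c2ccncc2)ccc1Cl` gives 811 nM in the same assay, the lower of the two numbers, though the step of a 1.5-fold lower number from compound 1 to compound 2 (0.18 log units; within the scatter) stays within the usual scatter, so the two cannot be ranked.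

Compound 3 `COc1cc(-c2nn(-c3cccc(NC(=O)c4ccc(Cl)c(C(F)(F)F)c4)c3)cc2-c2ccncc2)ccc1Cl` is the next compound. Relative to compound 2 the change is 4-chloro-3-(trifluoromethyl)phenyl in place of (3-(trifluoromethyl)phenyl)amino on a carbonyl carbon. This undoes the replacement seen between compound 1 and compound 2 and at the same time brings a chlorine onto the aromatic ring. Among the compounds with values here, the only measured step that bears on the change is a 1.5-fold lower number from compound 1 to compound 2 (0.18 log units; within the scatter), and it was small. With the chlorine there is no measured comparison at all, so the expectation for this assay rests on that single small step and is a number close to the two measured ones, with a step of a 1.2-fold higher number from compound 2 to compound 3 (0.07 log units; within the scatter) that is expected to stay within the scatter. Compound 3 is therefore estimated at 950 nM, with a likely range from 350 nM to 2600 nM.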

Compound 3, concentration for 50% growth inhibition: 1200 nM
Compound 3: middle estimate off by 1.3-fold (0.10 log units), on the low side; low and high end bracket the measured number.
By their numbers in this assay, from the lowest: compounds 2, 3 and 1 (each within the scatter of the next).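

Going by these compounds alone, compound 3 gives the first reading of a chlorine on this aromatic ring. In this assay, chloro in place of hydrogen on an aromatic carbon gives a 1.0-fold lower number from compound 1 to compound 3 (0.01 log units; within the scatter) and so cannot be told apart from no change at all on the amide of compound 1. Exchanging the (3-(trifluoromethyl)phenyl)amino group on the carbonyl carbon for 4-chloro-3-(trifluoromethyl)phenyl, which also takes away the hydrogen-bond donor counted in the leaving group, gives a 1.5-fold higher number from compound 2 to compound 3 (0.17 log units; within the scatter), so compounds 1, 2 and 3 cannot be ranked and neither change has shown a measurable effect in this series. No measurement is available that could explain these readings.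

The compounds shown leave open whether the same chlorine would read alike on the urea of compound 2, a comparison that would separate its contribution from that of the carbonyl neighbour. They also leave open whether a fluorine, a methoxy group or an amine such as dimethylamino in place of that chlorine would move the number beyond the usual scatter.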